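Oxadiazole ethyl homologue of compound 2: cytotoxicity outlook

A few compounds are considered here, and "the series" means these few. Any claim that something is new, unique, unknown or untested is made for them only; others in the source may bear on it.

Measured so far: compound 1 `CCCc1ccc(-c2ccc3ncc(-c4noc(C)n4)cc3c2)cc1` in a functional assay on RD cells (Homo sapiens) for inhibition, read by luminescence and ATP content, with a stated time of 72 h (on this read-out lower numbers stand for higher toxicity in this test and higher numbers for lower toxicity in this test), gives > 7400 nM, a limit of the assay. Compound 2 `Cc1nc(-c2cnc3ccc(-c4ccc(O)cc4)cc3c2)no1` gives > 2500 nM, a limit of the assay. Compound 3 `COc1ccc(-c2ccc3ncc(-c4noc(C)n4)cc3c2)cc1` gives > 66700 nM, a limit of the assay.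

Compound 2 therefore stands only at a limit, as do the other two values shown. Compound 4 `CCc1nc(-c2cnc3ccc(-c4ccc(O)cc4)cc3c2)no1` differs from compound 2 by methyl in place of hydrogen on a saturated chain carbon bound to an aromatic carbon. Among the measured compounds shown here, no measured step touches this position; the steps a step that the two limits leave unreadable from compound 1 to compound 2, a step that the two limits leave unreadable from compound 1 to compound 3 and a step that the two limits leave unreadable from compound 2 to compound 3 all run between limits (the limit of > 2500 nM in this assay, at which 1 of the 3 values shown sits, (the limit of > 66700 nM in this assay, at which 1 of the 3 values shown sits), (the limit of > 7400 nM in this assay, at which 1 of the 3 values shown sits)) and give no readable size. Nothing here supports a step beyond the scatter in either direction, and a further limit is the most likely outcome. Compound 4 is therefore expected to give 10000 nM, with a range from 2500 nM to 50000 nM. The step this expectation implies is a step that the limit leaves unreadable from compound 2 to compound 4.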

Compound 4, half-maximal cytotoxic concentration: > 2500 nM
Compound 4: no number, only a limit (the forecaster's own chance of this, stated with the estimate: 80%); the middle value is on the limit's open side.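

Compound 2 and compound 4 both stand only at a limit of the assay, so no step can be read between them: the limit of > 2500 nM in this assay, at which 2 of the 4 values shown sit.

The compounds shown leave open the size and direction of the methyl to ethyl change, since none of the four has a numerical cytotoxic concentration.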